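The source may hold more compounds than are shown below. What is called first, only, known or untested is meant among the compounds shown, and "the series" means these compounds.

Measured in a functional assay on Jurkat cells (Homo sapiens); a higher number here means a weaker inhibitor, a lower number a stronger inhibitor:
- Compound 1 `CC(C)[C@H](NC(=O)COc1cccc2ccccc12)C(=O)N[C@@H](CC(=O)O)C(=O)COc1ccc(OC(F)(F)F)cc1` gives 29100 nM
- Compound 2 `CC(=O)Nc1cccc(OCC(=O)[C@H](CC(=O)O)NC(=O)[C@@H](NC(=O)COc2cccc3ccccc23)C(C)C)c1` gives > 100000 nM, which is a limit of the assay and not a number
- Compound 3 `CC(C)[C@H](NC(=O)COc1cccc2ccccc12)C(=O)N[C@@H](CC(=O)O)C(=O)COc1c(Cl)cccc1Cl` gives 3000 nM

Compound 3 has the lowest number here, and the steps to it from both other compounds lie beyond the scatter. Compound 4 `CC(C)[C@H](NC(=O)COc1cccc2ccccc12)C(=O)N[C@@H](CC(=O)O)C(=O)COc1ccc([N+](=O)[O-])cc1F` keeps the rest of compound 3 and changes one group: 2-fluoro-4-nitrophenyl in place of 2,6-dichlorophenyl on an oxygen on a saturated carbon.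

All three measured steps change this same place. They are a 9.7-fold lower number from compound 1 to compound 3 (0.99 log units; beyond the scatter), an at least 33-fold lower number from compound 2 to compound 3 (1.52 log units; beyond the scatter) and an at least 3.4-fold higher number from compound 1 to compound 2 (0.53 log units; beyond the scatter). The group at this place can therefore move the number considerably in this assay. Among the compounds with values here, since compound 3 sits lowest at 3000 nM, a modest rise is expected on replacing its group, although only two other groups offer a comparison. The expected change is a 3.3-fold higher number from compound 3 to compound 4 (0.52 log units; beyond the scatter). For compound 4 the estimated value is 10000 nM, with an expected range from 2000 nM to 50000 nM.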

Compound 4, half-maximal inhibitory concentration: 30300 nM
Beside the measured number, compound 4's estimate is 3.0-fold (0.48 log units) below it; low and high end bracket the measured number.
By their numbers in this assay, from the lowest: compound 3; then compounds 1 and 4 (each within the scatter of the next). At a limit, above all of these: compound 2.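

In this assay, the low number at this position now belongs to 2,6-dichlorophenyl alone among the groups shown, and the new group does not keep it: a 10-fold higher number from compound 3 to compound 4 (1.00 log units; beyond the scatter). Replacing 4-(trifluoromethoxy)phenyl with 2-fluoro-4-nitrophenyl gives a 1.0-fold higher number from compound 1 to compound 4 (0.02 log units; within the scatter), so these two differently substituted rings cannot be told apart here. The value of compound 2 is a limit of the assay and not a number, so 3-acetamidophenyl can only be placed by a bounded step, an at least 3.3-fold lower number from compound 2 to compound 4 (0.51 log units; beyond the scatter), and that limit is the only one here: the limit of > 100000 nM in this assay, at which 1 of the 4 values shown sits.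

As far as these compounds go, it remains open whether a 2-chlorophenyl or 2,6-difluorophenyl group at this place would keep the low number of compound 3. Also open, from the compounds shown here alone, is what an amine or a plain alkyl chain would do in place of the ring.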